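Cyano for chloro on the benzamide ring

A few compounds are considered here, and "the series" means these few. Any claim that something is new, unique, unknown or untested is made for them only; others in the source may bear on it.

For the measured compounds named here, compound 2 `O=C(Nc1ccc(NS(=O)(=O)C(F)(F)F)c(Cl)c1)c1ccc(Cl)cc1` is the only compound with a number in an ADME assay on HEK293 cells (Homo sapiens) for cytotoxicity, read by MTT assay, with a stated time of 48 h (a lower number here means a stronger inhibitor, a higher number a weaker inhibitor), where compound 2 gives 191000 nM. Compound 1 `CS(=O)(=O)Nc1ccc(NC(=O)c2ccc(C#N)cc2)cc1Cl` sits at a limit of the assay in this assay, where compound 1 reads > 250000 nM. Going by the values given here, no step between two measured compounds can be drawn from this pair. Compound 3 `N#Cc1ccc(C(=O)Nc2ccc(NS(=O)(=O)C(F)(F)F)c(Cl)c2)cc1` differs from compound 2 by cyano in place of chloro on an aromatic carbon. Because the limit of > 250000 nM in this assay, at which 1 of the 2 values shown sits, already holds one of the two values, compound 3 may well return only a limit again. The step from compound 2 to compound 3 is expected to be small, a 1.3-fold higher number from compound 2 to compound 3 (0.12 log units; within the scatter), leaning, if anywhere, toward a weaker inhibitor. Compound 3 is therefore estimated at 250000 nM in this assay, with a plausible range from 120000 nM to 500000 nM.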

Compound 3, half-maximal inhibitory concentration: > 250000 nM
Compound 3 gave a limit, no number; the forecaster's own chance of this, stated with the estimate: 60%; the middle value lies on the limit itself.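

In this assay compound 3 reads > 250000 nM, which is a limit of the assay and not a number. Cyano in place of chloro on this aromatic carbon, para to a large group, yields only a floor for the step, an at least 1.3-fold higher number from compound 2 to compound 3 (0.11 log units; that floor lies within the scatter), so the change is not shown to exceed the usual scatter, though a larger step is not excluded. The step from compound 1 to compound 3, trifluoromethyl in place of methyl on a sulfonyl sulfur, cannot be read, because both ends are limits: the limit of > 250000 nM in this assay, at which 2 of the 3 values shown sit.

Going by these compounds, the true size of the change from chloro to cyano therefore remains open. Also unknown is whether an amine or a carboxylic acid on this same aromatic carbon would give a number clear of the limit.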